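Swapping the Nitrophenyl Arm for Thiophene: Cytotoxicity Outlook

The compounds below may be only part of what the source reports. "The series", "measured", "known", "first", "only" and "open" are said of these compounds alone.

Compound 1 `COc1cc(CC(O)c2ccc(-c3ccc([N+](=O)[O-])cc3)cc2)c([N+](=O)[O-])cc1OC` carries a 4-nitrophenyl group on the outer ring of the shared core. In an ADME assay on HeLa Rh cells (Homo sapiens) for cytotoxicity, read by microscopy (on this read-out lower numbers stand for higher toxicity in this test and higher numbers for lower toxicity in this test), compound 1 gives 21000 nM, the higher of the two numbers obtained so far, which marks it as the less toxic of the pair. Compound 2 `COc1cc(CC(O)c2ccc(-c3ccc(Br)cc3)cc2)c([N+](=O)[O-])cc1OC`, with bromo in place of nitro on an aromatic carbon, gives 4300 nM in this assay, and the step of a 4.9-fold lower number from compound 1 to compound 2 (0.69 log units; beyond the scatter) shows the number falling once the nitro group is gone. Compound 3 `COc1cc(CC(O)c2ccc(-c3cccs3)cc2)c([N+](=O)[O-])cc1OC` has not yet been tested in this assay. Its change from compound 1 is thiophen-2-yl in place of 4-nitrophenyl on an aromatic carbon. For the measured compounds named here, the only measured step bearing on it is a 4.9-fold lower number from compound 1 to compound 2 (0.69 log units; beyond the scatter), which also removed the nitro group, and on that basis a downward step of comparable size is expected for compound 3. Compound 3 is therefore estimated at 8000 nM, with a range from 2500 nM to 25000 nM. This estimate means an expected step of a 2.6-fold lower number from compound 1 to compound 3 (0.42 log units; beyond the scatter).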

Compound 3, half-maximal cytotoxic concentration: 11000 nM
Compound 3: the middle estimate sits 1.4-fold (0.14 log units) below what was measured; measured number inside the range.
By their numbers in this assay, from the lowest: compound 2; then compounds 3 and 1 (each within the scatter of the next).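

In this assay, putting thiophen-2-yl on this aromatic carbon gives a 1.9-fold lower number from compound 1 to compound 3 (0.28 log units; within the scatter), so this five-membered aromatic ring and the 4-nitrophenyl group cannot be told apart here. Removing the nitro group therefore does not by itself bring the large step seen with bromo, and a 2.6-fold higher number from compound 2 to compound 3 (0.41 log units; beyond the scatter) sets compound 2 apart as the compound with the lowest number of the three. No supporting data are available to explain this difference.

Three groups at one position cannot show whether the bromo atom itself sets compound 2 apart or whether this is specific to the 4-bromophenyl group as a whole. As far as these compounds go, it also remains open whether a phenyl ring carrying an amine or a carboxylic acid, or a thiophen-3-yl group, would fall closer to compound 2 or to compound 1 and compound 3.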